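This account rests on a few compounds, and the source may have more. Where it says the series, first, only, none or still open, it means among the compounds named here.

In a functional assay on KB cells (Homo sapiens), read by MTT assay (a lower number here means a stronger inhibitor, a higher number a weaker inhibitor), compound 1 `O=c1ccn([C@@H]2O[C@H](CO)[C@](O)(C3CC3)[C@H]2O)c(=O)[nH]1` gives > 350000 nM, which is a limit of the assay. Compound 2 `C#C[C@@]1(O)[C@H](O)[C@@H](CO)O[C@H]1n1ccc(N)nc1=O` gives > 350000 nM, also a limit, so no numerical potency is available for it. Both values sit at the same ceiling, as the limit of > 350000 nM in this assay, at which 2 of the 2 values shown sit, records. Compound 3 `C#C[C@]1(O)[C@H](O)[C@@H](CO)O[C@H]1n1ccc(N)nc1=O` differs from compound 2 only as follows: the two compounds have the same atoms and bonds and differ only in configuration as drawn: 1 of 4 stereo elements differ; a stereocentre at a saturated ring carbon is drawn R in compound 2 and S in compound 3. Among the measured compounds shown here, no measured step in this assay shows what such an inversion does, so the estimate is loose, leaning towards a stronger inhibitor or no change. The expected size of the change is an at least 3.5-fold lower number from compound 2 to compound 3 (0.54 log units; beyond the scatter). For compound 3 the estimated value is 100000 nM, with an expected range from 1000 nM to 350000 nM.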

Compound 3, half-maximal inhibitory concentration: > 350000 nM
Compound 3: only a limit was reported; the forecaster's own chance of this, stated with the estimate: 55%; middle value at least 3.5-fold (0.54 log units) from the limit.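

Compound 2 and compound 3 both stand only as limits in this assay, so no step between them can be read: the limit of > 350000 nM in this assay, at which 3 of the 3 values shown sit.

The compounds shown leave open whether the configuration at that saturated ring carbon matters at all in this assay: none of them has a numerical potency.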